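Propylamino in place of dimethylamino on a saturated ring carbon

This account rests on a few compounds, and the source may have more. Where it says the series, first, only, none or still open, it means among the compounds named here.

Going by the values given here, in an ADME assay on microsomes from liver (Rattus norvegicus) for metabolic stability, with a stated time of 10 min (on this read-out lower numbers stand for a less stable compound and higher numbers for a more stable compound), compound 2 `CN(C)[C@@H]1CC[C@H](NC(=O)CNC(=O)c2cccc(C(F)(F)F)c2)C[C@@H]1CS(=O)(=O)c1ccccc1` gives 3.9%, the lower of the two numbers so far, while compound 1 `CCN[C@@H]1CC[C@H](NC(=O)CNC(=O)c2cccc(C(F)(F)F)c2)C[C@@H]1CS(=O)(=O)c1ccccc1` gives 23% here. Compound 3 `CCCN[C@@H]1CC[C@H](NC(=O)CNC(=O)c2cccc(C(F)(F)F)c2)C[C@@H]1CS(=O)(=O)c1ccccc1` has propylamino in place of dimethylamino on a saturated ring carbon. Propylamino resembles the ethylamino of compound 1, so the one measured step that bears on this change, a number 19.1 percentage points lower from compound 1 to compound 2 (beyond the scatter), modest but beyond the scatter, is expected to run in reverse, perhaps less fully. Among the compounds with values here, no propylamino compound has been measured yet. The expected upward change is a number 13.1 percentage points higher from compound 2 to compound 3 (beyond the scatter) in this assay. Compound 3 is estimated at 17%, with a range of 6% to 32%.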

Compound 3, percent of the compound remaining: 8%
Compound 3: middle estimate off by 9 percentage points, on the high side, and the stated range covers the measured number.
By their numbers in this assay, from the lowest: compounds 2 and 3 (each within the scatter of the next); then compound 1.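

In this assay the swap to propylamino, which has a hydrogen-bond donor that dimethylamino lacks, gives a number 4.1 percentage points higher from compound 2 to compound 3 (within the scatter) and so that donor alone does not match compound 1. Methyl in place of hydrogen on the ethylamino chain gives a number 15 percentage points lower from compound 1 to compound 3 (beyond the scatter) and shows that this position also responds to chain length, not only to the kind of amine. Nothing measured here explains either step.

On these data alone, whether methylamino, cyclopropylamino or a longer butylamino chain on this carbon would stand nearer compound 1 or compound 3 remains open.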